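Fluoro step from compound 2 to compound 3

A few compounds are considered here, and "the series" means these few. Any claim that something is new, unique, unknown or untested is made for them only; others in the source may bear on it.

Of the compounds shown here, two have values so far in a functional assay on the whole organism with Mus musculus as the target; a lower number here means that less compound is needed, a higher number that more compound is needed for the effect. Compound 1 (`CC(C)NC(=O)/C=C1\CCc2ccc(F)cc21`) gives 96 mg/kg, and compound 2 (`NC(=O)/C=C1\CCc2ccccc21`) gives 108 mg/kg. These two values lie within the scatter of each other, so compound 2 stands level with compound 1 and the two cannot be ranked.

Compound 3 (`NC(=O)/C=C1\CCc2ccc(F)cc21`) has not yet been measured in this assay. It differs from compound 2 in one place: fluoro in place of hydrogen on an aromatic carbon. That is, fluoro in place of hydrogen on an aromatic carbon, para to a fused ring and meta to the other.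

For the measured compounds named here, no two measured compounds differ in only one place, so the series gives no direct measure of this change. The starting point is therefore compound 2 at 108 mg/kg. A modest move towards a lower dose is expected, although a result within the scatter would be no surprise. The estimated step of a 1.4-fold lower number from compound 2 to compound 3 (0.13 log units; within the scatter) reflects that expectation. Compound 3 is expected at 80 mg/kg, with an estimated range of 40 mg/kg to 165 mg/kg.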

Compound 3, dose for half-maximal effect: 56 mg/kg
Compound 3: middle estimate off by 1.4-fold (0.15 log units), on the high side, and the stated range covers the measured number.
By their numbers in this assay, from the lowest: compounds 3, 1 and 2 (each within the scatter of the next).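

In this assay the series now has its first direct readings of single changes. Fluoro in place of hydrogen on the aromatic carbon, meta to a fused ring and para to a fused ring, gives a 1.9-fold lower number from compound 2 to compound 3 (0.29 log units; within the scatter), so at this position the change from hydrogen to fluoro cannot be told apart from the usual spread of repeated measurements. With the fluoro held in place, hydrogen in place of isopropyl on the amide-type nitrogen gives a 1.7-fold lower number from compound 1 to compound 3 (0.23 log units; within the scatter), so the two nitrogen substituents cannot be separated here either, and nothing available bears on the reason for either step.

Going by these compounds, it remains open whether a different group at this aromatic position, such as chloro, methoxy or a nitrile, or a fluoro on another aromatic carbon, would move the number beyond the scatter. On these data alone, on the amide-type nitrogen, the effect of a methyl group, a longer chain or a chain carrying an amine is also open, as is whether the isopropyl step would read the same with hydrogen in place of the fluoro.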